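This account rests on a few compounds, and the source may have more. Where it says the series, first, only, none or still open, it means among the compounds named here.

Measured in a functional assay on A549 cells (Homo sapiens) for inhibition, read by MTT assay, with a stated time of 72 h; a higher number here means a weaker inhibitor, a lower number a stronger inhibitor:
- compound 1 `O=C1/C(=C\c2ccccc2)c2c(ncn2COCc2ccccc2)CCN1Cc1ccccc1`: 9900 nM
- compound 2 `Cc1cccc(CN2CCc3ncn(COCc4ccccc4)c3/C(=C/c3ccccc3)C2=O)c1`: 16100 nM
- compound 3 `O=C1/C(=C\c2ccccc2)c2c(ncn2COCc2ccccc2)CCN1Cc1ccc(Cl)cc1`: 11800 nM

Compound 1 cannot be separated from the other two, with a 1.2-fold higher number from compound 1 to compound 3 (0.08 log units; within the scatter) and a 1.6-fold higher number from compound 1 to compound 2 (0.21 log units; within the scatter). Compound 4 `O=C1/C(=C\c2ccncc2)c2c(ncn2COCc2ccccc2)CCN1Cc1ccccc1` departs from compound 1 by this change: pyridin-4-yl in place of phenyl on a double-bonded chain carbon bound to a double-bonded ring carbon. In words, pyridin-4-yl stands in place of phenyl on a double-bonded chain carbon bound to a double-bonded ring carbon. Among the measured compounds shown here, no measured step touches that place, since both steps from compound 1 are changes elsewhere in the molecule and stay small. The series therefore offers no ground for expecting a step beyond the scatter in this assay, in either direction, though the untested place keeps the range wide. The expected step is a 1.1-fold higher number from compound 1 to compound 4 (0.05 log units; within the scatter). For compound 4 the estimate is 11000 nM, with an expected range of 4500 nM to 26000 nM.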

Compound 4, half-maximal inhibitory concentration: 36000 nM
The estimate for compound 4 lay 3.3-fold (0.51 log units) below the measured number; the measured number lies above the stated range.
By their numbers in this assay, from the lowest: compounds 1, 3 and 2 (each within the scatter of the next); then compound 4.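

In this assay, among the compounds shown here, the place on a double-bonded chain carbon bound to a double-bonded ring carbon responds to a change of ring, whereas the earlier steps, all elsewhere in the molecule, stayed within the scatter. Pyridin-4-yl in place of phenyl gives a 3.6-fold higher number from compound 1 to compound 4 (0.56 log units; beyond the scatter), a modest step but the only one shown beyond the scatter. Nothing measured here accounts for this step.

From the compounds shown here alone, whether an amine or a carboxylic acid on the phenyl at this place would move the number in either direction remains open. So does whether pyridin-4-yl gives a similar step alongside the 4-chlorophenyl of compound 3.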